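Matched pairs of bis-benzylidene piperidinones in a liver-cell toxicity assay

The source may hold more compounds than are shown below. What is called first, only, known or untested is meant among the compounds shown, and "the series" means these compounds.

Compound 1 `COc1cc(/C=C2\CN(C)C/C(=C\c3ccc(Br)cc3)C2=O)cc(OC)c1` gives 21300 nM in an ADME assay on L02 cells (Homo sapiens) for cytotoxicity, read by MTT assay, with a stated time of 24 h; on this read-out lower numbers stand for stronger inhibition and higher numbers for weaker inhibition. Compound 2 `COc1cc(/C=C2\CN(C)C/C(=C\c3ccc(Cl)cc3Cl)C2=O)cc(OC)c1` gives 18800 nM. Compound 3 `COc1cc(/C=C2\CN(C)C/C(=C\c3ccc(Br)cc3)C2=O)cc(OC)c1OC` gives 15400 nM.

The three values sit within the usual scatter of one another, so none of them stands apart. Compound 2 differs from compound 1 by 2,4-dichlorophenyl in place of 4-bromophenyl on a double-bonded chain carbon bound to a double-bonded ring carbon, and that change brought a 1.1-fold lower number from compound 1 to compound 2 (0.05 log units; within the scatter). Compound 3 differs from compound 1 by methoxy in place of hydrogen on an aromatic carbon, with a 1.4-fold lower number from compound 1 to compound 3 (0.14 log units; within the scatter).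

Compound 4 `COc1cc(/C=C2\CN(C)C/C(=C\c3ccc(Cl)cc3Cl)C2=O)cc(OC)c1OC` has not yet been measured. Within the data shown here, it differs from compound 3 by 2,4-dichlorophenyl in place of 4-bromophenyl on a double-bonded chain carbon bound to a double-bonded ring carbon, which is the same change as the one from compound 1 to compound 2, made on the same place and on a core that itself differs only as described for compound 3. Because that earlier change gave a 1.1-fold lower number from compound 1 to compound 2 (0.05 log units; within the scatter), the step from compound 3 to compound 4 is expected to be a 1.1-fold lower number from compound 3 to compound 4 (0.04 log units; within the scatter) in this assay, a step that stays inside the scatter. On that basis compound 4 is estimated at 14000 nM, with a likely range from 7000 nM to 28000 nM.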

Compound 4, half-maximal inhibitory concentration: 13400 nM
For compound 4 the middle estimate is 1.0-fold (0.02 log units) above the measured one; low and high end bracket the measured number.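

In this assay, putting 2,4-dichlorophenyl in place of 4-bromophenyl gave a 1.1-fold lower number from compound 3 to compound 4 (0.06 log units; within the scatter), and this step repeats the one seen on the core of compound 1: the same change on two cores in this assay, a 1.1-fold lower number (0.05 log units; within the scatter) from compound 1 to compound 2 and a 1.1-fold lower number (0.06 log units; within the scatter) from compound 3 to compound 4, 1.0-fold (0.01 log units) apart, within the scatter of two such steps. Adding methoxy on an aromatic carbon gave a 1.4-fold lower number from compound 2 to compound 4 (0.15 log units; within the scatter), and this step also repeats on the second core: the same change on two cores in this assay, a 1.4-fold lower number (0.14 log units; within the scatter) from compound 1 to compound 3 and a 1.4-fold lower number (0.15 log units; within the scatter) from compound 2 to compound 4, 1.0-fold (0.01 log units) apart, within the scatter of two such steps. Each change therefore carried from one core to the other with no detectable difference across these four compounds, but every step lies within the scatter, so this does not show that either change has a real effect on the number or that the match would hold on other cores.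

On these data alone, it remains open whether a different kind of group on an aromatic carbon, such as an amine or a carboxylic acid, would give a step beyond the scatter. The compounds shown also leave open whether either change would carry over in the same way on a more different core.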